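Nitro in place of methyl: compound 3 in the series

A few compounds are considered here, and "the series" means these few. Any claim that something is new, unique, unknown or untested is made for them only; others in the source may bear on it.

In an ADME assay on H9 cells (Homo sapiens) for cytotoxicity, read by XTT assay, with a stated time of 6 days (on this read-out higher numbers stand for lower toxicity in this test and lower numbers for higher toxicity in this test), compound 1 (`Cc1ccc(Nc2cc(Oc3c(C)cc(Br)cc3C)c([N+](=O)[O-])cc2[N+](=O)[O-])cc1`) gives 53000 nM. Among the compounds with values here, compound 2 (`Cc1cccc(C)c1Oc1cc(Nc2ccc(C#N)cc2)c(N)cc1N`) gives 53200 nM, so the only two measured numbers lie within the scatter of each other, and compound 1 stands level with compound 2. Compound 3 (`Cc1cc(Br)cc(C)c1Oc1cc(Nc2ccc([N+](=O)[O-])cc2)c([N+](=O)[O-])cc1[N+](=O)[O-]`) keeps the core of compound 1 but has nitro in place of methyl on an aromatic carbon, para to a large group, which turns 4-methylphenyl into 4-nitrophenyl: nitro in place of methyl on an aromatic carbon. Within the data shown here, no measured pair shows this change, and compound 2 differs from compound 1 in more than one place, so the expectation rests on little. A modest move towards a lower number in this assay is expected, estimated as a 1.8-fold lower number from compound 1 to compound 3 (0.25 log units; within the scatter), and a result within the scatter would be no surprise. For compound 3 the estimated value is 30000 nM, with an expected range of 8000 nM to 100000 nM.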

Compound 3, half-maximal cytotoxic concentration: > 49700 nM
Compound 3: a limit, no number; the forecaster's own chance of this, stated with the estimate: 15%; at least 1.6-fold (0.21 log units) between middle value and limit.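

No step can be read from compound 1 to compound 3. In this assay compound 3 gives > 49700 nM, which is a limit and not a number. On these data alone, whether nitro in place of methyl on an aromatic carbon shifts the read-out, and in which direction, stays open.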